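A few compounds are considered here, and "the series" means these few. Any claim that something is new, unique, unknown or untested is made for them only; others in the source may bear on it.

Measured compounds in a functional assay on HCT-116 cells (Homo sapiens) for antiproliferative activity, read by MTT assay, with a stated time of 48 h; on this read-out lower numbers stand for stronger inhibition and higher numbers for weaker inhibition:

compound 1, `N#CC1=C(N)Oc2c(c3nc4ccccc4nc3c3ccccc23)C12C(=O)N(Cc1cnnn1-c1ccc(F)c(Cl)c1)c1ccccc12` — in this assay compound 1 gives only a limit, > 50000 nM.
compound 2, `N#CC1=C(N)Oc2c(c3nc4ccccc4nc3c3ccccc23)C12C(=O)N(Cc1cnnn1-c1ccc(Cl)c(Cl)c1)c1ccccc12` — in this assay compound 2 gives only a limit, > 50000 nM.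
compound 3, `N#CC1=C(N)Oc2c(N)cc3nc4ccccc4nc3c2C12C(=O)N(Cc1cnnn1-c1ccc(F)cc1)c1ccccc12` — in this assay compound 3 gives only a limit, > 50000 nM.

Compound 1 and compound 2 differ by chloro in place of fluoro on an aromatic carbon. The step that the two limits leave unreadable from compound 1 to compound 2 has no readable size, because both values sit at the limit of > 50000 nM in this assay, at which 3 of the 3 values shown sit. How the core of compound 3 differs from that of compound 1 is not broken down here.

Compound 4, `N#CC1=C(N)Oc2c(N)cc3nc4ccccc4nc3c2C12C(=O)N(Cc1cnnn1-c1ccc(Cl)cc1)c1ccccc12`, is not yet measured in this assay. It differs from compound 3 by chloro in place of fluoro on an aromatic carbon. The place differs from the earlier pair only in that the earlier one is also ortho to a chloro group (1 heavy atom), so this is the same kind of change, not the same one.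

Since compound 3 and both of the earlier pair sit at the limit of > 50000 nM in this assay, at which 3 of the 3 values shown sit, no movement away from the limit is expected. The step that the limit leaves unreadable from compound 3 to compound 4 is accordingly expected to be unreadable as well. Compound 4 is estimated to give 80000 nM in this assay, again most likely reported only as a limit.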

Compound 4, half-maximal inhibitory concentration: > 50000 nM
Compound 4: no number, only a limit; the forecaster's own chance of this, stated with the estimate: 85%; the middle value does not contradict the limit.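

No step between compound 3 and compound 4 can be read in this assay, because both results are limits and not numbers: the limit of > 50000 nM in this assay, at which 4 of the 4 values shown sit.

The compounds shown leave open how large the change from fluoro to chloro is on either core, and whether the two cores differ at all in this assay.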